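The source may report more compounds than this note shows. Statements on the series, on what has been measured and on what is new or still open speak of the compounds shown alone.

Among the compounds with values here, in a functional assay on A-375 cells (Homo sapiens) for inhibition, read by MTT assay, with a stated time of 120 h (on this read-out higher numbers stand for weaker inhibition and lower numbers for stronger inhibition), compound 2 `CC(NC(=O)/C=C/c1ccc(NC(=O)Nc2ccc(Cl)c(C(F)(F)F)c2)cc1)c1ccccc1` gives 20800 nM, the only actual number available so far. Compound 1 `C/C(=C\c1ccc(NC(=O)Nc2ccc(Cl)c(C(F)(F)F)c2)cc1)C(=O)NC(C)c1ccccc1` gives only a limit of the assay, > 50000 nM. Compound 3 `CC1CN(C(=O)/C=C/c2ccc(NC(=O)Nc3ccc(Cl)c(C(F)(F)F)c3)cc2)CC(C)O1` carries 2,6-dimethylmorpholin-4-yl in place of (1-phenylethyl)amino on a carbonyl carbon. Within the data shown here, no measured pair of compounds shows this exchange, so the expectation is only a rough one. The expected change, a 1.2-fold higher number from compound 2 to compound 3 (0.08 log units; within the scatter), is small, leans towards weaker inhibition and may stay within the usual scatter. For compound 3 the estimated value is 25000 nM, with an expected range from 9000 nM to 50000 nM.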

Compound 3, half-maximal inhibitory concentration: > 50000 nM
Compound 3 ended at the assay's limit; the forecaster's own chance of this, stated with the estimate: 30%; middle value at least 2.0-fold (0.30 log units) away from the limit.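

In this assay, putting 2,6-dimethylmorpholin-4-yl in place of (1-phenylethyl)amino on this carbonyl carbon gives an at least 2.4-fold higher number from compound 2 to compound 3 (0.38 log units; beyond the scatter), so this position does not take the exchange without a loss of inhibition. That step is only a minimum, and its full size cannot be read, since it rests on a limit: the limit of > 50000 nM in this assay, at which 2 of the 3 values shown sit.

The compounds shown leave open whether the loss follows the aromatic ring or the amide hydrogen, both of which leave with (1-phenylethyl)amino. A cyclohexylamino or a piperidin-1-yl group on the same carbonyl carbon would help separate the two.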